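The source may hold more compounds than are shown below. What is called first, only, known or untested is meant among the compounds shown, and "the series" means these compounds.

Measured in a functional assay on the whole organism (strain albino Sprague-Dawley) with Rattus norvegicus as the target, in the maximal electroshock model; a higher number here means that more compound is needed for the effect, a lower number that less compound is needed:
compound 1 `CC(C)(C)[C@@H](N)C(=O)NCc1ccc(OCc2cccc(F)c2)cc1`: > 30 mg/kg (a limit of the assay, not a number)
compound 2 `CC(C)(C)[C@@H](N)C(=O)NCc1ccc(OC(F)(F)F)cc1`: 23 mg/kg
compound 3 `CC(C)(C)[C@@H](N)C(=O)NCc1ccc(Cl)cc1`: 30 mg/kg

Compound 3 holds the highest of the two numbers in this assay, with compound 2 nearest, and the step of a 1.3-fold higher number from compound 2 to compound 3 (0.12 log units; within the scatter) stays within the scatter. For compound 1 the result is only a limit of this assay (the limit of > 30 mg/kg in this assay, at which 1 of the 3 values shown sits). Compound 4 `CC(C)(C)[C@@H](N)C(=O)NCc1ccc(C(F)(F)F)cc1` differs from compound 3 in one place: trifluoromethyl in place of chloro on an aromatic carbon. Among the compounds with values here, two measured steps bear on this exchange of the group on the aromatic carbon. The step of an at least 1.3-fold lower number from compound 1 to compound 2 (0.11 log units; that floor lies within the scatter) has a floor within the scatter, and the step of a 1.3-fold higher number from compound 2 to compound 3 (0.12 log units; within the scatter) also lies within it. Hence no change beyond the scatter is expected, no change at the digits printed from compound 3 to compound 4 (within the scatter). Compound 4 is estimated at 30 mg/kg in this assay, with a range from 15 mg/kg to 60 mg/kg.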

Compound 4, dose for half-maximal effect: < 30 mg/kg
Compound 4: only a limit was reported; the forecaster's own chance of this, stated with the estimate: 35%; the middle value lies on the limit itself.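

In this assay the result for compound 4 is only a limit of the assay, not a number: the limit of < 30 mg/kg in this assay, at which 1 of the 4 values shown sits.

With trifluoromethyl in place of chloro on this aromatic carbon, the step is a number no higher from compound 3 to compound 4 (the limit leaves the size open), so the group with more heavy atoms does not raise the dose needed. The step involving compound 2 and compound 4 cannot be read.

The compounds shown leave open how large the change from chloro to trifluoromethyl really is, and whether it goes beyond the scatter. They also leave open what an amine or a carboxylic acid on this aromatic carbon would give.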